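Swapping a Pyrrole for a Pyridine on the Oxadiazole

This account rests on a few compounds, and the source may have more. Where it says the series, first, only, none or still open, it means among the compounds named here.

Four compounds share one core, a dithiocarbamate built from pyridin-3-ylmethylamine and a two-carbon chain that ends in a heteroaromatic ring. Compound 1 `S=C(NCc1cccnc1)SCCc1nnn[nH]1` carries a tetrazole there, compound 2 `S=C(NCc1cccnc1)SCCc1nc2ccccc2o1` a benzoxazole, compound 3 `S=C(NCc1cccnc1)SCCc1nnc(-c2cc[nH]c2)o1` an oxadiazole bearing a pyrrole, and compound 4 `S=C(NCc1cccnc1)SCCc1nnc(-c2cccnc2)o1` the same oxadiazole bearing a pyridine instead. Three of them have been tested in a functional assay on MDA-MB-468 cells (Homo sapiens) for cytotoxicity, read by resazurin assay, with a stated time of 72 h; a lower number here means a stronger inhibitor, a higher number a weaker inhibitor.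

In this assay, among the measured compounds shown here, compound 1 gives > 100000 nM, which is a limit of the assay rather than a number; it is the only compound sitting at the limit of > 100000 nM in this assay, at which 1 of the 3 values shown sits. Compound 2 gives 4300 nM, and compound 3 gives 2040 nM, the lower of the two numbers obtained so far, with a gap to compound 2 that lies beyond the usual scatter.

Compound 4 differs from compound 3 in one place: pyridin-3-yl in place of 1H-pyrrol-3-yl on an aromatic carbon. For the measured compounds named here, no measured pair shows what this kind of swap does, so the expectation rests on the structural change alone. The step from compound 3 to compound 4 is expected to be small, a 1.2-fold higher number from compound 3 to compound 4 (0.09 log units; within the scatter), and not clearly beyond the scatter in either direction. Compound 4 is therefore estimated at 2500 nM, with a plausible range from 900 nM to 7000 nM.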

Compound 4, half-maximal inhibitory concentration: 3160 nM
The estimate for compound 4 lay 1.3-fold (0.10 log units) below the measured number, within the range that was stated.
By their numbers in this assay, from the lowest: compounds 3, 4 and 2 (each within the scatter of the next, the first and the last beyond it). At a limit, above all of these: compound 1.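

In this assay, this carbon of the oxadiazole accepts a change of ring with no clear shift in the read-out: the exchange of 1H-pyrrol-3-yl for pyridin-3-yl gives a 1.5-fold higher number from compound 3 to compound 4 (0.19 log units; within the scatter). The group that leaves has a hydrogen-bond donor and no acceptor, the group that enters has an acceptor and no donor, and a five-membered aromatic ring gives way to a six-membered one, yet compound 3 and compound 4 cannot be told apart in this assay. Nothing among the data shown explains why so large a change in the ring leaves the two values within the scatter of each other.

The compounds shown place only these two aromatic rings on this carbon, so it stays open whether phenyl, pyridin-4-yl, a methyl group or an amine there would keep the value in the same range. As far as these compounds go, it also stays open how a longer chain in place of the shared one would behave, and whether any such change could move the value clearly beyond the scatter.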